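Pyridyl ester repositioning on a ketone-linked FAAH series

This account rests on a few compounds, and the source may have more. Where it says the series, first, only, none or still open, it means among the compounds named here.

Measured compounds:
compound 1 `COC(=O)c1cc(-c2cnc(C(=O)CCc3ccc(-c4ccccc4)cc3)o2)ccn1`: 1.5 nM
compound 2 `O=C(CCc1ccc(COc2ccccc2)cc1)c1ncco1`: 25 nM

In an assay for inhibition of Fatty-acid amide hydrolase 1 (Rattus norvegicus) (on this read-out higher numbers stand for weaker inhibition and lower numbers for stronger inhibition), compound 1 gives the lowest number of the two. Compound 2, measured in the same assay, gives 25 nM, a higher number than compound 1 and a gap beyond the usual scatter. Compound 1 therefore stands as the stronger of the two inhibitors on the numbers shown.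

Compound 3 `COC(=O)c1ccc(-c2cnc(C(=O)CCc3ccc(-c4ccccc4)cc3)o2)cn1` is not yet measured. It is built from the same atoms as compound 1, joined differently: 6-(methoxycarbonyl)pyridin-3-yl in place of 2-(methoxycarbonyl)pyridin-4-yl on an aromatic carbon. The group that leaves and the group that enters have the same count of heavy atoms, donors and acceptors; only the point at which the pyridine ring is attached to the five-membered aromatic ring with 1 nitrogen and 1 oxygen, and the position of the methoxycarbonyl on that pyridine, change.

Among the compounds with values here, no measured pair in this set shows the effect of such a repositioning, so the expected step from compound 1 to compound 3 is uncertain; a small loss in inhibition, of a size near the edge of the scatter, is estimated, a 2.0-fold higher number from compound 1 to compound 3 (0.30 log units; within the scatter). Compound 3 is expected to give 3 nM in this assay, within a range of 0.7 nM to 15 nM.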

Compound 3, inhibition constant: 0.6 nM
Estimate against measurement, compound 3: 5.0-fold (0.70 log units) above; the whole stated range lies above it.
By their numbers in this assay, from the lowest: compound 3; then compound 1; then compound 2.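

In this assay, within the data shown here, 6-(methoxycarbonyl)pyridin-3-yl in place of 2-(methoxycarbonyl)pyridin-4-yl, on the aromatic carbon next to the ring oxygen, gives a 2.5-fold lower number from compound 1 to compound 3 (0.40 log units; beyond the scatter) and is the only change in this set that can be read in one place. The step is modest, but it shows that this position responds to how the pyridine and its methoxycarbonyl are arranged, even though the heavy atoms, donors and acceptors of the group are the same on both sides. No measurement offers an explanation for the direction of this step.

Attachment point and ester placement change together in this pair, so the step cannot be assigned to either one alone, and other arrangements of the same pyridine remain open. Also open, from the compounds shown here alone, is how much of the result depends on the methoxycarbonyl itself: a carboxylic acid, a primary amide or a plain pyridin-3-yl at this position of the shared core would test that directly.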